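The source may hold more compounds than are shown below. What is called first, only, known or untested is meant among the compounds shown, and "the series" means these compounds.

Measured so far in a functional assay on HeLa cells (Homo sapiens) for cytotoxicity, read by MTT assay, with a stated time of 48 h; a lower number here means a stronger inhibitor, a higher number a weaker inhibitor: compound 1 `COc1ccc(-c2cc(C(=O)Nc3nc4ccc(Cl)cc4s3)nc3cc(-c4ccccc4)nn23)cc1` gives 5880 nM; compound 2 `COc1ccc(-c2cc(C(=O)Nc3nc4ccc(F)cc4s3)nc3cc(-c4ccccc4)nn23)cc1` gives 41700 nM; compound 3 `COc1ccc2nc(NC(=O)c3cc(-c4ccc(F)cc4)n4nc(-c5ccccc5)cc4n3)sc2c1` gives 17300 nM.

Compound 3 stands second highest of these three numbers in this assay. Its nearest neighbour is compound 2, whose number is higher; the furthest is compound 1, whose number is lower; both gaps lie beyond the usual scatter. Among the compounds with values here, the one step that can be compared across a single change is a 7.1-fold higher number from compound 1 to compound 2 (0.85 log units; beyond the scatter), which concerns the ring on the amide side of the shared core, not the ring that is altered here.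

Compound 4 `COc1ccc(-c2cc(C(=O)Nc3nc4ccc(OC)cc4s3)nc3cc(-c4ccccc4)nn23)cc1` differs from compound 3 by methoxy in place of fluoro on an aromatic carbon, the group sitting para to a large group. Within the data shown here, no measured pair shows a fluoro exchanged for a methoxy on this ring, so the one known step gives only a sense of how far a single substituent swap can move the number. Compound 4 is therefore expected to sit close to compound 3, with a step of a 1.2-fold lower number from compound 3 to compound 4 (0.06 log units; within the scatter) and an estimated value of 15000 nM, in the range 5000 nM to 45000 nM.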

Compound 4, half-maximal inhibitory concentration: 24500 nM
For compound 4 the middle estimate is 1.6-fold (0.21 log units) below the measured one, within the range that was stated.
By their numbers in this assay, from the lowest: compound 1; then compounds 3, 4 and 2 (each within the scatter of the next, the first and the last beyond it).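

In this assay, within the data shown here, the change from 4-fluorophenyl to 4-methoxyphenyl gives a 1.4-fold higher number from compound 3 to compound 4 (0.15 log units; within the scatter) and so offers the first reading at this position: this exchange does not separate the two compounds. The same exchange of fluoro for methoxy on the ring on the amide side of the shared core gives a 1.7-fold lower number from compound 2 to compound 4 (0.23 log units; within the scatter) and likewise stays inside the scatter. On that ring, methoxy in place of chloro gives a 4.2-fold higher number from compound 1 to compound 4 (0.62 log units; beyond the scatter) and, with a 7.1-fold higher number from compound 1 to compound 2 (0.85 log units; beyond the scatter) as the other step from chloro, sets compound 1 apart from both compound 2 and compound 4.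

On these data alone, whether an amine or a carboxylic acid in place of the methoxy of 4-methoxyphenyl would move the number beyond the scatter stays open. Nothing shown here explains these steps.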